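A few compounds are considered here, and "the series" means these few. Any claim that something is new, unique, unknown or untested is made for them only; others in the source may bear on it.

Measured so far in a functional assay on DU-145 cells (Homo sapiens) for inhibition, read by trypan blue exclusion, with a stated time of 96 h; a higher number here means a weaker inhibitor of growth, a lower number a stronger inhibitor of growth:
Compound 1, `O=C(/C(=C\c1ccc(Cl)cc1)SCc1ccc(F)cc1)c1ccc(Cl)cc1`, gives 10000 nM.
Compound 2, `Cc1ccsc1/C=C(/SCc1ccc(F)cc1)C(=O)c1ccc(Cl)cc1`, gives 50000 nM.
Compound 3, `O=C(/C(=C\c1ccc(O)cc1)SCc1ccc(F)cc1)c1ccc(Cl)cc1`, gives 25000 nM.

Compound 3 holds the second highest of the three numbers. Its nearest neighbour is compound 2, at a 2.0-fold lower number from compound 2 to compound 3 (0.30 log units; within the scatter); its furthest is compound 1, at a 2.5-fold higher number from compound 1 to compound 3 (0.40 log units; beyond the scatter). The remaining step, a 5.0-fold higher number from compound 1 to compound 2 (0.70 log units; beyond the scatter), was modest. Compound 4, `O=C(/C(=C\c1ccc(O)cc1)SCc1ccc(Cl)cc1)c1ccc(Cl)cc1`, differs from compound 3 by chloro in place of fluoro on an aromatic carbon. Within the data shown here, none of the three measured steps touches the (4-fluorobenzyl)sulfanyl part: each concerns the other aryl group, so no step bears directly on this exchange. With nothing in the numbers pointing either way, compound 4 is expected to sit close to compound 3, with no change at the digits printed from compound 3 to compound 4 (within the scatter) falling within the scatter. Compound 4 is therefore estimated at 25000 nM in this assay, with a range of 10000 nM to 60000 nM.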

Compound 4, concentration for 50% growth inhibition: 10000 nM
Beside the measured number, compound 4's estimate is 2.5-fold (0.40 log units) above it; measured number inside the range.
By their numbers in this assay, from the lowest: compounds 1 and 4 (each within the scatter of the next); then compounds 3 and 2 (each within the scatter of the next).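

In this assay the (4-fluorobenzyl)sulfanyl part proves able to move the number: chloro in place of fluoro gives a 2.5-fold lower number from compound 3 to compound 4 (0.40 log units; beyond the scatter) and is the first step shown at this position, a modest one beyond the scatter, whereas the earlier steps all concerned the other aryl group. No measurement shown here accounts for this step. As far as these compounds go, it remains open whether a bromo, methyl, methoxy or amine group at this position would follow chloro or fluoro. From the compounds shown here alone, it also remains open whether the same exchange gives a similar step with 4-chlorophenyl or 3-methylthiophen-2-yl in place of 4-hydroxyphenyl.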